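The source may report more compounds than this note shows. Statements on the series, on what has been measured and on what is new or still open speak of the compounds shown alone.

Of the compounds shown here, three from this series have been measured in a functional assay on A549 cells (Homo sapiens) for inhibition, read by sulforhodamine B assay, with a stated time of 48 h; on this read-out lower numbers stand for stronger inhibition of growth and higher numbers for weaker inhibition of growth. Compound 1, `COc1cc(C)cc(-c2c(-c3ccnc(-c4ccc(C(C)=O)cc4)c3)cnn2CC#N)c1`, gives 3680 nM in this assay. Compound 2, `COc1cc(C)cc(-c2nn(CC#N)cc2-c2ccc(-c3cccc(C(C)=O)c3)nc2)c1`, gives 3870 nM in this assay. Compound 3, `Cc1cc(O)cc(-c2nn(CC#N)cc2-c2ccnc(-c3ccc(Oc4ccccc4)cc3)c2)c1`, gives 2000 nM in this assay. Among these three numbers compound 3 has the lowest one, but its gap to compound 1 and its gap to compound 2 both lie within the usual scatter of repeated measurements, so the three compounds cannot be placed in any order of growth inhibition on these data.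

The next compound, compound 4, `Cc1cc(O)cc(-c2nn(CC#N)cc2-c2ccnc(-c3ccc(N(C)C)cc3)c2)c1`, differs from compound 3 in a single place: dimethylamino in place of phenoxy on an aromatic carbon. Among the measured compounds shown here, no pair of measured compounds in this set differs by this or any other single change, so there is no measured step from which the size of this one could be read. With nothing to point in either direction, the expectation is that compound 4 will stay within the scatter of compound 3 in this assay, with the estimated step from compound 3 to compound 4 being a 1.3-fold higher number from compound 3 to compound 4 (0.10 log units; within the scatter). The value expected for compound 4 in this assay is 2500 nM, with a likely range from 800 nM to 8000 nM.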

Compound 4, concentration for 50% growth inhibition: 4180 nM
Estimate against measurement, compound 4: 1.7-fold (0.22 log units) below; measured number inside the range.
By their numbers in this assay, from the lowest: compounds 3, 1, 2 and 4 (each within the scatter of the next, the first and the last beyond it).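

In this assay, among the compounds shown here, dimethylamino in place of phenoxy, on an aromatic carbon para to a large group, gives a 2.1-fold higher number from compound 3 to compound 4 (0.32 log units; beyond the scatter), the first single change in this set whose size can be read. The step is modest but beyond the scatter, so this position is not indifferent to what it carries: growth inhibition is weaker with dimethylamino than with phenoxy. The change removes a six-membered aromatic ring of carbon only and goes from 7 heavy atoms to 3, while the counts of hydrogen-bond donors and acceptors stay the same, but no measurement here ties the step to any one of these differences.

On these data alone, with a single replacement at this position, it remains open where a cyclic amine such as morpholine, a small ether such as methoxy or a carboxylic acid would fall relative to compound 3 and compound 4. As far as these compounds go, it also remains open whether the same exchange would give a step of similar size on a core carrying methoxy in place of the hydroxyl of compound 3.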